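Hydroxy on the 3,5-dimethoxyphenyl group of compound 3

The compounds below may be only part of what the source reports. "The series", "measured", "known", "first", "only" and "open" are said of these compounds alone.

In a functional assay on HeLa cells (Homo sapiens) for cytotoxicity, read by MTT assay, with a stated time of 72 h (on this read-out higher numbers stand for weaker inhibition and lower numbers for stronger inhibition), compound 1 `O=C(/C=C/c1ccc([N+](=O)[O-])cc1)Nc1cc2c(Nc3ccc(F)c(Cl)c3)ncnc2cc1O[C@H]1CCOC1` gives 27400 nM and compound 3 `COc1cc(/C=C/C(=O)Nc2cc3c(Nc4ccc(F)c(Cl)c4)ncnc3cc2O[C@H]2CCOC2)cc(OC)c1` gives 34300 nM, two values within the scatter of each other. Compound 2 `N#Cc1ccc(/C=C/C(=O)Nc2cc3c(Nc4ccc(F)c(Cl)c4)ncnc3cc2O[C@H]2CCOC2)cc1` has no number: "not determined" (no result reported).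

Compound 4 `COc1cc(/C=C/C(=O)Nc2cc3c(Nc4ccc(F)c(Cl)c4)ncnc3cc2O[C@H]2CCOC2)cc(OC)c1O` replaces 3,5-dimethoxyphenyl with 4-hydroxy-3,5-dimethoxyphenyl: hydroxy in place of hydrogen on an aromatic carbon. The new hydroxy stands ortho to two methoxy groups and para to a large group.

For the measured compounds named here, one measured step bears on this group, a 1.3-fold higher number from compound 1 to compound 3 (0.10 log units; within the scatter), and it exchanges 4-nitrophenyl for 3,5-dimethoxyphenyl. Going by the values given here, no measured step adds a hydroxy, so the support is thin. No step beyond the scatter is expected in this assay. The estimated step is a 1.1-fold lower number from compound 3 to compound 4 (0.06 log units; within the scatter). For compound 4 the expected value is 30000 nM, with an estimated range of 12000 nM to 65000 nM.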

Compound 4, half-maximal inhibitory concentration: 27400 nM
Estimate against measurement, compound 4: 1.1-fold (0.04 log units) above, within the range that was stated.
By their numbers in this assay, from the lowest: compounds 1, 4 and 3 (each within the scatter of the next).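

In this assay the step of a 1.3-fold lower number from compound 3 to compound 4 (0.10 log units; within the scatter) shows that a hydroxy on this aromatic carbon, ortho to two methoxy groups, leaves the number within the scatter. The step of no change at the digits printed from compound 1 to compound 4 (within the scatter) likewise places the 4-hydroxy-3,5-dimethoxyphenyl group within the scatter of the 4-nitrophenyl group. No evidence given here accounts for these results.

Still open, on these data alone, is whether an amine or a carboxylic acid on this carbon would give a step beyond the scatter. The same holds for a longer chain in place of the two methoxy groups.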